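Pyridin-4-yl Replaces Cyclopropyl on the Amide Carbonyl

The source may report more compounds than this note shows. Statements on the series, on what has been measured and on what is new or still open speak of the compounds shown alone.

Compound 1 `Cc1[nH]nc(N)c1-c1ccc2ccccc2c1`: > 100000 nM in an assay on Sf9 cells for inhibition of mitogen-activated protein kinase kinase kinase 14 (Homo sapiens), read by ADP-Glo, with a stated time of 60 min (a lower number here means a stronger inhibitor, a higher number a weaker inhibitor), a limit of the assay.
Compound 2 `Cc1[nH]nc(N)c1-c1ccc(Br)cc1`: > 100000 nM in this assay, also a limit.
Compound 3 `Cc1nn(C(=O)C2CC2)c(N)c1-c1ccc(Cl)c(Cl)c1`: 24300 nM in this assay.

Compound 3 is the only one of the three to give a number at all; the other two sit at the limit (the limit of > 100000 nM in this assay, at which 2 of the 3 values shown sit). Compound 4 `Cc1nn(C(=O)c2ccncc2)c(N)c1-c1ccc(Cl)c(Cl)c1` differs from compound 3 by pyridin-4-yl in place of cyclopropyl on a carbonyl carbon. Among the measured compounds shown here, no measured pair of compounds differs in just one place, so no measured step shows how large such a change tends to be. The step from compound 3 to compound 4 is expected to be a modest gain, a 2.4-fold lower number from compound 3 to compound 4 (0.39 log units; beyond the scatter), somewhat beyond the scatter. Compound 4 is therefore estimated at 10000 nM, within a range of 2000 nM to 60000 nM.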

Compound 4, half-maximal inhibitory concentration: 58200 nM
Compound 4: the middle estimate sits 5.8-fold (0.76 log units) below what was measured; low and high end bracket the measured number.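

Placing pyridin-4-yl instead of cyclopropyl on the carbonyl carbon gives the first readable step at this position, and it points toward a weaker inhibitor in this assay: a 2.4-fold higher number from compound 3 to compound 4 (0.38 log units; beyond the scatter). A larger aromatic ring containing a nitrogen therefore still leaves a readable number, but it brings no gain over the small carbon ring. Nothing given here explains the direction of this step.

Going by these compounds, with only these two groups on the carbonyl carbon, it remains open how a plain phenyl ring, an amine or a longer carbon chain would compare. A phenyl ring would also help show whether the ring nitrogen of pyridin-4-yl matters to this step.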